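Bromo for chloro on a shared amide scaffold

The source may hold more compounds than are shown below. What is called first, only, known or untested is meant among the compounds shown, and "the series" means these compounds.

Compound 1 `Cn1ccc2c(Oc3ccc(NC(=O)c4cc5cccnc5n(-c5ccc(Cl)cc5)c4=O)cc3)ncnc21` and compound 2 `Cn1ccc2c(Oc3ccc(NC(=O)c4cc5cccnc5n(-c5ccc(Br)cc5)c4=O)cc3)ncnc21` differ by a single change, (bromo in place of chloro on an aromatic carbon), and in a functional assay on A549 cells (Homo sapiens) for cytotoxicity, read by MTT assay, with a stated time of 72 h (on this read-out lower numbers stand for stronger inhibition and higher numbers for weaker inhibition), compound 1 gives 75500 nM while compound 2 gives 52200 nM, so that the step is a 1.4-fold lower number from compound 1 to compound 2 (0.16 log units; within the scatter). Compound 3 `O=C(Nc1ccc(Oc2ncnc3[nH]ccc23)c(F)c1)c1cc2cccnc2n(-c2ccc(Cl)cc2)c1=O` carries a different core; the difference between the two cores is not broken down here. In this assay compound 3 gives 35500 nM. Compound 4 `O=C(Nc1ccc(Oc2ncnc3[nH]ccc23)c(F)c1)c1cc2cccnc2n(-c2ccc(Br)cc2)c1=O` is derived from compound 3 by bromo in place of chloro on an aromatic carbon, the same change as that from compound 1 to compound 2. The step expected from compound 3 to compound 4 is estimated as a 1.3-fold lower number from compound 3 to compound 4 (0.12 log units; within the scatter), resting on the measured 1.4-fold lower number from compound 1 to compound 2 (0.16 log units; within the scatter). Compound 4 is therefore expected to give 27000 nM in this assay, with a range estimated from 12000 nM to 60000 nM.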

Compound 4, half-maximal inhibitory concentration: 27300 nM
Beside the measured number, compound 4's estimate is 1.0-fold (0.00 log units) below it; the range from low to high includes it.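

In this assay, bromo in place of chloro on the 4-chlorophenyl group gives a 1.3-fold lower number from compound 3 to compound 4 (0.11 log units; within the scatter). Set beside the earlier step, the change reads alike on the two cores: the same change on two cores in this assay, a 1.4-fold lower number (0.16 log units; within the scatter) from compound 1 to compound 2 and a 1.3-fold lower number (0.11 log units; within the scatter) from compound 3 to compound 4, 1.1-fold (0.05 log units) apart, within the scatter of two such steps. Carried from one core to the other, the change thus behaves consistently, but both steps lie within the scatter, so the pair does not establish that bromo differs from chloro on either core, and two cores cannot speak for the whole series.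

The compounds shown leave open whether another group in that place, such as an amine, a methoxy or a trifluoromethyl, would shift the number beyond the scatter. They also leave open whether the same change would read alike on further cores.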